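The compounds below may be only part of what the source reports. "The series", "measured", "known", "first", "only" and "open" are said of these compounds alone.

Measured so far:
compound 1, `COC(=O)[C@@H](O)[C@H]1C(=O)N2C(C(=O)O)=C(C(C)(C)C)O[C@H]12`, gives 6.2 h
compound 2, `COC(=O)[C@H](O)[C@H]1C(=O)N2C(C(=O)O)=C(C(C)(C)C)O[C@H]12`, gives 6.7 h

Both numbers come from an ADME assay, in phosphate buffer, at 28 degrees C, at pH 7.0; a higher number here means that the compound lasts longer, a lower number that the compound disappears faster. Compound 2 has the top number of the two, yet the step from compound 1 to compound 2 a 1.1-fold higher number from compound 1 to compound 2 (0.03 log units; within the scatter) lies within the scatter, so the two compounds cannot be told apart on this read-out. The two differ only in the configuration drawn at one stereocentre on a saturated chain carbon (the fact that compounds 1 and 2 differ only in the configuration as drawn), and with that change the half-life stays essentially where it was.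

Compound 3, `CC(C)(C)C1=C(C(=O)O)N2C(=O)[C@H]([C@@H](O)c3ccncc3)[C@H]2O1`, is not yet measured. Compared with compound 2 the change is pyridin-4-yl in place of methoxycarbonyl on a saturated chain carbon bound to an oxygen on a saturated carbon and a saturated ring carbon. Going by the values given here, no measured step touches this kind of exchange: the only step available, from compound 1 to compound 2, concerns configuration alone and leaves every group in place. The expectation therefore rests on nothing more than the shared core and the size of the swap, and for compound 3 a step of a 1.0-fold lower number from compound 2 to compound 3 (0.01 log units; within the scatter) in this assay is estimated, with no direction that can be claimed beyond the scatter. The estimate for compound 3 in this assay is 6.5 h, expected to fall between 2.5 h and 16 h.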

Compound 3, half-life: 6 h
Compound 3: middle estimate off by 1.1-fold (0.03 log units), on the high side; measured number inside the range.
By their numbers in this assay, from the lowest: compounds 3, 1 and 2 (each within the scatter of the next).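

The saturated chain carbon bound to an oxygen on a saturated carbon and a saturated ring carbon can take pyridin-4-yl in place of methoxycarbonyl, and in this assay this exchange gives a 1.1-fold lower number from compound 2 to compound 3 (0.05 log units; within the scatter). Until now, this position had been probed only by a change of configuration; here the group itself changes, from one with no ring to a six-membered aromatic ring, and the two compounds still cannot be told apart on half-life. Nothing available accounts for this result, since the only supporting fact concerns configuration and not an exchange of groups.

Going by these compounds, whether an amine, a carboxylic acid or a longer chain on this carbon would also stay within the scatter remains open. Also open, on these data alone, is whether pyridin-4-yl would give a similar half-life with the opposite configuration at this carbon, and whether the number in this assay is set by the shared core rather than by the group at this position.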